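Swapping ethyl for an aryl group on the ring nitrogen

A few compounds are considered here, and "the series" means these few. Any claim that something is new, unique, unknown or untested is made for them only; others in the source may bear on it.

The series is built around a shared core carrying three methoxy groups, and it was tested in a functional assay on HCT-15 cells (Homo sapiens) for antiproliferative activity, read by MTT assay, with a stated time of 72 h; on this read-out higher numbers stand for weaker inhibition and lower numbers for stronger inhibition. Compound 1 `CCn1ccnc1-c1cc(OC)c(OC)c(OC)c1` stands only at a limit of this assay, returning > 100000 nM rather than a number. In this assay compound 2 `COc1cc(-c2nccn2-c2ccc3cc[nH]c3c2)cc(OC)c1OC` gives 4000 nM. The unmeasured compound 3 `COc1cc(-c2nccn2-c2ccc(Br)cc2)cc(OC)c1OC` differs from compound 1 by 4-bromophenyl in place of ethyl on an aromatic nitrogen. Going by the values given here, no measured pair differs in a single place, so the size of the step from compound 1 to compound 3 can only be expected, not read off; compound 2 shows that a compound bearing an aromatic group in place of an alkyl group on that nitrogen reaches a measurable value. Compound 3 is therefore expected to gain potency beyond the scatter, a step of an at least 12-fold lower number from compound 1 to compound 3 (1.09 log units; beyond the scatter). The value of compound 3 in this assay is estimated at 8000 nM, between 1500 nM and 50000 nM.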

Compound 3, half-maximal inhibitory concentration: 11700 nM
Compound 3: the middle estimate sits 1.5-fold (0.17 log units) below what was measured, within the range that was stated.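

Going by these compounds alone, compound 3 gives this position on the aromatic nitrogen its first comparison in which only one place changes: in this assay, 4-bromophenyl in place of ethyl brings an at least 8.5-fold lower number from compound 1 to compound 3 (0.93 log units; beyond the scatter). This places the gain beyond the scatter and ties it to this single change, with the rest of the shared core held the same. The true size of the step stays unknown, and the figure is only a lower bound because one end of it is a limit and not a number: the limit of > 100000 nM in this assay, at which 1 of the 3 values shown sits.

The compounds shown leave open how much of the gain belongs to the phenyl ring and how much to the bromine, a question that plain phenyl or 4-chlorophenyl at this nitrogen would address. They also leave open whether a longer chain, such as butyl, would move the value at all.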